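Methyl for hydrogen on a phenolic oxygen, second time

The source may report more compounds than this note shows. Statements on the series, on what has been measured and on what is new or still open speak of the compounds shown alone.

Measured compounds:
- compound 1, `CC1(/C=C/c2ccccc2O)C=CC(=O)O1`, 31300 nM
- compound 2, `CC1(/C=C/c2cccc(O)c2)C=CC(=O)O1`, 97400 nM
- compound 3, `COc1ccccc1/C=C/C1(C)C=CC(=O)O1`, 30800 nM

All three were tested in a functional assay on HT-29 cells (Homo sapiens) for inhibition, read by sulforhodamine B assay, with a stated time of 48 h; on this read-out higher numbers stand for weaker inhibition of growth and lower numbers for stronger inhibition of growth. Compound 2 gives the highest of the three numbers, and its gap to compound 1 and to compound 3 is beyond the scatter. Compound 1 and compound 2 are built from the same atoms joined differently; the difference between the two cores is not broken down here.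

Compound 3 differs from compound 1 by one change, (methyl in place of hydrogen on an oxygen on an aromatic ring). In this assay this step is a 1.0-fold lower number from compound 1 to compound 3 (0.01 log units; within the scatter), so the change left the read-out essentially where it was.

Compound 4, `COc1cccc(/C=C/C2(C)C=CC(=O)O2)c1`, has not yet been measured. It differs from compound 2 by the same kind of change, (methyl in place of hydrogen on an oxygen on an aromatic ring), and the two place descriptions are identical word for word. Among the compounds with values here, since the one measured example of this change, from compound 1 to compound 3, moved the number hardly at all, the expectation is that compound 4 will sit close to compound 2, with an estimated step of a 1.0-fold lower number from compound 2 to compound 4 (0.01 log units; within the scatter). On that basis compound 4 is expected to give about 95000 nM in this assay, with a likely range from 40000 nM to 220000 nM. This rests on a single precedent, so the estimate is held loosely.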

Compound 4, concentration for total growth inhibition: 17000 nM
Compound 4: the middle estimate sits 5.6-fold (0.75 log units) above what was measured; measured number outside the range, below it.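

In this assay, replacing hydroxy with methoxy on the core of compound 2 gives a 5.7-fold lower number from compound 2 to compound 4 (0.76 log units; beyond the scatter), so on this core the added methyl goes with stronger inhibition of growth. The same change therefore does not carry over from one core to the other with the same size, and a result on one core would have been a poor guide to the other: the same change on two cores in this assay, a 1.0-fold lower number (0.01 log units; within the scatter) from compound 1 to compound 3 and a 5.7-fold lower number (0.76 log units; beyond the scatter) from compound 2 to compound 4, 5.6-fold (0.75 log units) apart, beyond the scatter of two such steps

With only two pairs, this shows that the size of the step depends on the core among these compounds, but it does not show why, and it gives no rule for what the step would be on a further core.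

The compounds shown carry only hydroxy or methoxy on the aromatic ring, so it remains open what a longer chain on that oxygen, such as ethoxy, or an amine in place of the hydroxy would do on either core. Also open, as far as these compounds go, is whether the two cores would part in the same way on a different read-out, since all of these comparisons rest on this assay.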